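Working notes: a larger acyl group on compound 3

The compounds below may be only part of what the source reports. "The series", "measured", "known", "first", "only" and "open" are said of these compounds alone.

- Compound 1 `O=c1[nH]c2ccc(Cl)cc2c(-c2ccccc2Cl)c1CCO`: 380000 nM
- Compound 2 `CCC(=O)OCCc1c(-c2ccccc2Cl)c2cc(Cl)ccc2[nH]c1=O`: 95000 nM
- Compound 3 `COCC(=O)OCCc1c(-c2ccccc2Cl)c2cc(Cl)ccc2[nH]c1=O`: 74000 nM

In an ADME assay on HepG2 2.2.15 cells (Homo sapiens) for cytotoxicity (on this read-out lower numbers stand for higher toxicity in this test and higher numbers for lower toxicity in this test), compound 3 sits at the low end of the three numbers, though not apart from compound 2. Methoxy in place of methyl on the acyl chain gave only a 1.3-fold lower number from compound 2 to compound 3 (0.11 log units; within the scatter), whereas the acyl groups themselves gave a 4.0-fold lower number from compound 1 to compound 2 (0.60 log units; beyond the scatter) and a 5.1-fold lower number from compound 1 to compound 3 (0.71 log units; beyond the scatter).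

Compound 4 `O=C(CCC1CCCCC1)OCCc1c(-c2ccccc2Cl)c2cc(Cl)ccc2[nH]c1=O` carries cyclohexylmethyl in place of methoxy on a saturated chain carbon bound to a carbonyl carbon. For the measured compounds named here, only the step of a 1.3-fold lower number from compound 2 to compound 3 (0.11 log units; within the scatter) touches this place, and no measured compound has a ring there. A small move toward lower numbers is therefore expected, possibly none beyond the scatter. The expected step is a 1.5-fold lower number from compound 3 to compound 4 (0.17 log units; within the scatter). For compound 4 the estimated value is 50000 nM, with an expected range of 15000 nM to 130000 nM.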

Compound 4, half-maximal cytotoxic concentration: 160000 nM
For compound 4 the middle estimate is 3.2-fold (0.51 log units) below the measured one; measured number above the stated range.
By their numbers in this assay, from the lowest: compounds 3, 2 and 4 (each within the scatter of the next, the first and the last beyond it); then compound 1.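

Notes on the acyl position: in this assay the methoxy-to-cyclohexylmethyl change gives a 2.2-fold higher number from compound 3 to compound 4 (0.33 log units; beyond the scatter) and is the first change at this place to go beyond the scatter. The ring-bearing ester is not separated from the propanoyl ester, with a 1.7-fold higher number from compound 2 to compound 4 (0.23 log units; within the scatter) within the scatter. It still stays on the lower side of the alcohol, with a 2.4-fold lower number from compound 1 to compound 4 (0.38 log units; beyond the scatter) as the step. No measurement at hand bears on the cause of these steps.

Open: whether an amine, a carboxylic acid or a longer open chain on the acyl group would stay with the esters or move toward compound 1.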